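Swapping a Side Chain on the Core of Compound 1

The source may report more compounds than this note shows. Statements on the series, on what has been measured and on what is new or still open speak of the compounds shown alone.

Measured compounds:
- compound 1, `O=C(CN(c1ncnc2c1ncn2C1CCCCO1)C1CC1)N[C@@H](CCC(=O)OCc1ccccc1)C(=O)OCc1ccccc1`: 20.7%
- compound 2, `O=C(OCc1ccccc1)[C@@H]1CCCN1C(=O)CN(c1nc(Cl)nc2[nH]cnc12)C1CC1`: 38.4%
- compound 3, `C[C@@H](O)[C@H](NC(=O)CN(c1nc(Cl)nc2[nH]cnc12)C1CC1)C(=O)OCc1ccccc1`: 30.7%

All three were tested in a functional assay on the whole organism (Tail, strain ICR) with Mus musculus as the target, in the tail flick test, with a stated time of 120 min, at a dose of 25 umol/kg by the oral route; a lower number here means a weaker effect, a higher number a stronger effect of the compound at the dose given. Among the three numbers, compound 1 stands lowest. Its nearest neighbour is compound 3, whose value lies within the usual scatter of compound 1, so the two cannot be told apart. Compound 2 sits further away, beyond the scatter, and so shows a clearly stronger effect than compound 1.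

Compound 4, `CC(C)[C@H](NC(=O)CN(c1ncnc2c1ncn2C1CCCCO1)C1CC1)C(=O)OCc1ccccc1`, keeps the core of compound 1 and changes only one side chain: isopropyl in place of 2-(benzyloxycarbonyl)ethyl on a saturated chain carbon bound to an amide-type nitrogen and a carbonyl carbon. For the measured compounds named here, no pair of measured compounds differs in one place, so there is no measured step from which the size of this change can be read. All three values fall in a narrow band, and the change touches only a chain at the amide-bearing carbon. The expected step of a number 6.3 percentage points higher from compound 1 to compound 4 (within the scatter) is therefore small and not beyond the scatter, with a slight lean upward since compound 1 is the lowest of the three values.

For compound 4 the estimate in this assay is 27%, expected to fall between 12% and 42%.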

Compound 4, a percentage reported as activity, at one dose (the size of the read-out at that dose, not a potency): 25.8%
Compound 4: the middle estimate sits 1.2 percentage points above what was measured; the measured number falls inside the stated range.
By their numbers in this assay, from the lowest: compounds 1, 4, 3 and 2 (each within the scatter of the next, the first and the last beyond it).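

In this assay, for the compounds shown here, the change on the shared core gives a number 5.1 percentage points higher from compound 1 to compound 4 (within the scatter), which is the first measured step in which only one place differs. On this saturated chain carbon bound to an amide-type nitrogen and a carbonyl carbon, 2-(benzyloxycarbonyl)ethyl, with 12 heavy atoms and a six-membered aromatic ring, can therefore give way to isopropyl, with 3 heavy atoms and no ring, and the two compounds cannot be told apart at this single dose. No measurement shown here bears on why the read-out stays so close after so large a loss of atoms.

The compounds shown leave open whether a carboxylic acid, an amine or a longer straight carbon chain at this same carbon would also stay within the scatter of compound 1, or would produce a step beyond it. Compound 2 and compound 3 differ from compound 1 and compound 4 in more than one place, so they cannot show what any single part of the structure contributes.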